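Methoxy to hydrogen on the shared core: next step

This account rests on a few compounds, and the source may have more. Where it says the series, first, only, none or still open, it means among the compounds named here.

Measured so far in a functional assay on MOLT-4 cells (Homo sapiens) for inhibition, read by sulforhodamine B assay, with a stated time of 48 h; on this read-out higher numbers stand for weaker inhibition of growth and lower numbers for stronger inhibition of growth:
- compound 1, `COc1ccc(-c2cc(/C=C/C(=O)c3ccc(N)cc3)[nH]n2)cc1`: 2320 nM
- compound 2, `COc1ccc(-c2cc(/C=C/C(=O)c3ccc(N)cc3)[nH]n2)cc1OC`: 3110 nM
- compound 3, `COc1cc(C(=O)/C=C/c2cc(-c3cc(OC)c(OC)c(OC)c3)n[nH]2)cc(OC)c1OC`: 2320 nM

Compound 2 and compound 1 differ in one place, (hydrogen in place of methoxy on an aromatic carbon), and the step is a 1.3-fold lower number from compound 2 to compound 1 (0.13 log units; within the scatter). Compound 3 and compound 1 show the same number at the digits given, and compound 3 against compound 2 shows the smaller number by a margin that is also within the scatter; no ranking is drawn from any of this. The difference between the core of compound 3 and the core of compound 2 is not broken down here.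

Compound 4, `COc1ccc(-c2cc(/C=C/C(=O)c3cc(OC)c(OC)c(OC)c3)[nH]n2)cc1OC`, is not yet measured. Going by the values given here, it is reached from compound 3 by hydrogen in place of methoxy on an aromatic carbon, the same kind of change as the one from compound 2 to compound 1; around the place the surroundings are not identical, as in compound 3 the carbon is also meta to a methoxy group, whereas in compound 2 that is not the case. In this assay the step is expected to be a 1.0-fold lower number from compound 3 to compound 4 (0.00 log units; within the scatter), which rests on the single earlier occurrence, a 1.3-fold lower number from compound 2 to compound 1 (0.13 log units; within the scatter), being within the scatter. Compound 4 is therefore expected to give 2300 nM in this assay. Among the compounds with values here, the expected range for compound 4 runs from 1100 nM to 4800 nM; only one prior step of this kind is available, so the range is kept wide.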

Compound 4, concentration for 50% growth inhibition: 1810 nM
For compound 4 the middle estimate is 1.3-fold (0.10 log units) above the measured one, within the range that was stated.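

In this assay, hydrogen in place of methoxy on an aromatic carbon gives a 1.3-fold lower number from compound 3 to compound 4 (0.11 log units; within the scatter), and the two occurrences of this change can be set side by side: the same change on two cores in this assay, a 1.3-fold lower number (0.13 log units; within the scatter) from compound 2 to compound 1 and a 1.3-fold lower number (0.11 log units; within the scatter) from compound 3 to compound 4, 1.0-fold (0.02 log units) apart, within the scatter of two such steps. On these two cores the change therefore carries over with no difference that can be read, even though the surroundings of the place are not identical. Each step is itself within the scatter, however, so what carries over is the lack of a readable effect on growth inhibition, not a gain, and two occurrences do not show that methoxy can be replaced by hydrogen without consequence on other cores or at other places in the series.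

The compounds shown leave open how the number responds when the methoxy group at this place gives way to something other than hydrogen, such as a hydroxy group, a chlorine atom or a carboxylic acid. Also open, as far as these compounds go, is whether the same replacement keeps its size in other cell lines or on a core whose number lies far from those seen here.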